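A few compounds are considered here, and "the series" means these few. Any claim that something is new, unique, unknown or untested is made for them only; others in the source may bear on it.

In a functional assay on MCF7 cells (Homo sapiens) for inhibition, read by sulforhodamine B assay (on this read-out lower numbers stand for stronger inhibition and higher numbers for weaker inhibition), compound 1 `O=C1C=C(NC2CCCCC2)C(=O)c2c1nc1n2[C@H]2OC[C@@H](O)[C@H]2OC1` reaches no number, only a limit of > 8000 nM. On the same core, compound 2 `COc1ccc(NC2=CC(=O)c3c(nc4n3[C@H]3OC[C@@H](O)[C@H]3OC4)C2=O)cc1` gives a measured 4470 nM. Compound 3 `COc1ccccc1NC1=CC(=O)c2nc3n(c2C1=O)[C@H]1OC[C@@H](O)[C@H]1OC3` carries 2-methoxyphenyl in place of cyclohexyl on an amine nitrogen of compound 1: 2-methoxyphenyl in place of cyclohexyl on an amine nitrogen. Within the data shown here, the expectation for it leans on compound 2, whose 4470 nM is the only true number available. A small shift towards stronger inhibition in this assay is therefore expected, with the estimated step being an at least 1.7-fold lower number from compound 1 to compound 3 (0.24 log units; that floor lies within the scatter). For compound 3 the estimated value is 4500 nM, with an expected range of 1800 nM to 11000 nM.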

Compound 3, half-maximal inhibitory concentration: > 4000 nM
Compound 3 ended at the assay's limit; the forecaster's own chance of this, stated with the estimate: 30%; the middle value lies beyond the limit too.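

Compound 1 gives only a limit (> 8000 nM). Among these compounds, compound 3 likewise gives only a limit (> 4000 nM), so no step between them can be read. Going by these compounds, whether 2-methoxyphenyl in place of cyclohexyl changes inhibition at all remains open.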